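The compounds below may be only part of what the source reports. "The series", "measured", "known", "first", "only" and "open" are said of these compounds alone.

The measured compounds are three: compound 1 `COc1ccc(C(=O)/C=C/c2cc(OC)c(OC)c(OC)c2)c2c1C=CC(C)(C)O2` with 9150 nM, compound 2 `COc1ccc(C(=O)/C=C/c2cccc(F)c2)c2c1C=CC(C)(C)O2`, and compound 3 `COc1ccc(C(=O)/C=C/c2ccc3ccccc3c2)c2c1C=CC(C)(C)O2` with 2140 nM. All were tested in a functional assay on SW-620 cells (Homo sapiens) for antiproliferative activity, read by MTT assay, with a stated time of 24 h; on this read-out higher numbers stand for weaker inhibition and lower numbers for stronger inhibition. For compound 2 this assay reports only a limit and no number, > 10000 nM. The value of compound 2 is the limit of > 10000 nM in this assay, at which 1 of the 3 values shown sits. Compound 2 thus stands at the limit of the numbers shown, while compound 1 and compound 3 each give a number.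

The unmeasured compound 4 `COc1ccccc1/C=C/C(=O)c1ccc(OC)c2c1OC(C)(C)C=C2` differs from compound 2 in one place: 2-methoxyphenyl in place of 3-fluorophenyl on a double-bonded chain carbon bound to a double-bonded chain carbon. Among the compounds with values here, no step between two measured compounds is available to set a scale for this change, so the expectation rests on the three values alone. Since compound 1 and compound 3 both give numbers and compound 2 gives only a limit, compound 4 is expected to sit near or a little inside that limit. Compound 4 is estimated at 9000 nM, with a range from 3500 nM to 25000 nM. The expected step is an at least 1.1-fold lower number from compound 2 to compound 4 (0.04 log units; that floor lies within the scatter), which is not expected to exceed the scatter.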

Compound 4, half-maximal inhibitory concentration: > 10000 nM
Compound 4 gave a limit, no number; the forecaster's own chance of this, stated with the estimate: 45%; middle value at least 1.1-fold (0.04 log units) from the limit.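

In this assay compound 4 gives only a limit, > 10000 nM, and compound 2 also gives only a limit, so no step can be read between these two compounds. The compounds shown leave open whether 2-methoxyphenyl in place of 3-fluorophenyl changes the read-out at all.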